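Swapping the Sulfonamide Aryl Group on a Shared Core

The source may hold more compounds than are shown below. What is called first, only, known or untested is meant among the compounds shown, and "the series" means these compounds.

Compound 2 `NS(=O)(=O)c1ccc(-c2nc(C(c3ccc(F)cc3)c3ccc(F)cc3)sc2CC(=O)O)cc1` and compound 1 `N#Cc1cc(-c2nc(C(c3ccc(F)cc3)c3ccc(F)cc3)sc2CC(=O)O)ccc1F` share the same core and differ only in the aryl group attached to it. In an in vitro functional assay on HEK285-7 cells for antagonist activity at prostaglandin D2 receptor 2 (Homo sapiens), read by BRET and beta-arrestin recruitment (a lower number here means a stronger inhibitor, a higher number a weaker inhibitor), compound 1 gives 520 nM. For compound 2 the assay returns only a limit, > 100000 nM, so its true number is not known; this reading sits at the limit of > 100000 nM in this assay, at which 1 of the 2 values shown sits. The step of an at least 190-fold higher number from compound 1 to compound 2 (2.28 log units; beyond the scatter) is large, and compound 2 stands as the weaker of the two measured compounds.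

Compound 3 `CS(=O)(=O)Nc1cccc(-c2nc(C(c3ccc(F)cc3)c3ccc(F)cc3)sc2CC(=O)O)c1` is not yet measured. It changes compound 2 by 3-(methanesulfonamido)phenyl in place of 4-sulfamoylphenyl on an aromatic carbon. Going by the values given here, the only measured step that bears on this position is the one from compound 1 to compound 2, and it shows that exchanging the aryl group can move the result far beyond the scatter. Compound 3 keeps a sulfonamide-containing group, though of a different kind, so a full return toward the number of compound 1 is uncertain. Compound 3 is expected to land around 20000 nM, between 2000 nM and 100000 nM. That estimate means an expected step of an at least 5.0-fold lower number from compound 2 to compound 3 (0.69 log units; beyond the scatter), with a further limit readout remaining possible.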

Compound 3, half-maximal inhibitory concentration: 370 nM
The estimate for compound 3 lay 54-fold (1.73 log units) above the measured number, and the stated range ends above it.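

Exchanging the aryl group at this position gives an at least 270-fold lower number from compound 2 to compound 3 (2.43 log units; beyond the scatter) in this assay and so shows that a sulfonamide-containing group is not in itself ruled out here: the outcome depends on which such group is attached. The second step, a 1.4-fold lower number from compound 1 to compound 3 (0.15 log units; within the scatter) in this assay, lies within the scatter, so 3-(methanesulfonamido)phenyl and 3-cyano-4-fluorophenyl cannot be told apart in this measurement, even though they are quite different groups. As far as these compounds go, the full size of the first step stays unknown, as the reading for compound 2 is a limit and not a number: the limit of > 100000 nM in this assay, at which 1 of the 3 values shown sits.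

The step from 4-sulfamoylphenyl to 3-(methanesulfonamido)phenyl changes both where the group sits on the phenyl ring and how the sulfonamide is built, so the compounds shown cannot separate these two changes; 3-sulfamoylphenyl and 4-(methanesulfonamido)phenyl would be the groups that could do so. From the compounds shown here alone, it also stays open how this position would respond to a group without sulfur or a nitrile, such as a 3-aminophenyl or a 3-carboxyphenyl group.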